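From 3-methoxyphenyl to 4-methoxyphenyl in compound 3

A few compounds are considered here, and "the series" means these few. Any claim that something is new, unique, unknown or untested is made for them only; others in the source may bear on it.

In a functional assay on the whole organism (strain Kunming) with Mus musculus as the target, with a stated time of 0.5 h (a lower number here means that less compound is needed, a higher number that more compound is needed for the effect), compound 1 `COc1ccccc1/C=C/C(=O)OC/C=C/c1cc(OC)c(OC)cc1OC` gives 39 mg/kg and compound 2 `COc1cccc(/C=C/C(=O)OC/C=C/c2cc(OC)c(OC)cc2OC)c1` gives 72.9 mg/kg. Among the compounds with values here, compound 2 therefore stands within the scatter of compound 1, the only other compound measured so far. Compound 3 `COc1ccc(/C=C/C(=O)OC/C=C/c2cc(OC)c(OC)cc2OC)cc1` has not yet been measured. It carries 4-methoxyphenyl in place of 3-methoxyphenyl on a double-bonded chain carbon bound to a double-bonded chain carbon. Within the data shown here, only one measured step bears on this change: a 1.9-fold higher number from compound 1 to compound 2 (0.27 log units; within the scatter), in which 3-methoxyphenyl takes the place of 2-methoxyphenyl at the same place. That step lies within the scatter and offers no ground for expecting a large shift. The expected change is small, a 1.3-fold lower number from compound 2 to compound 3 (0.12 log units; within the scatter), and is not expected to exceed the scatter. For compound 3 the estimate is 55 mg/kg, with an expected range from 24 mg/kg to 120 mg/kg.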

Compound 3, dose for half-maximal effect: 70.6 mg/kg
The estimate for compound 3 lay 1.3-fold (0.11 log units) below the measured number, within the range that was stated.
By their numbers in this assay, from the lowest: compounds 1, 3 and 2 (each within the scatter of the next).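

With compound 3, the 2-methoxyphenyl, 3-methoxyphenyl and 4-methoxyphenyl groups can all be compared on a double-bonded chain carbon bound to a double-bonded chain carbon in this assay. Within the data shown here, the new comparisons give a 1.0-fold lower number from compound 2 to compound 3 (0.01 log units; within the scatter) and a 1.8-fold higher number from compound 1 to compound 3 (0.26 log units; within the scatter), so moving the methoxy group around this phenyl ring separates none of the three compounds beyond the scatter, a statement that the single earlier step could not make for all three groups. No separate measurement is available to account for this result.

All three compounds carry a methoxy group on this phenyl ring, so they leave open what an amine, a carboxylic acid or a longer chain such as butoxy would do at this place. From the compounds shown here alone, the rest of the shared core is identical in all three, so the effect of a change there also remains open.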